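The compounds below may be only part of what the source reports. "The series", "measured", "known", "first", "only" and "open" are said of these compounds alone.

For the measured compounds named here, in a functional assay on HCT-116 cells (Homo sapiens) for antiproliferative activity, read by MTT assay, with a stated time of 72 h (on this read-out lower numbers stand for stronger inhibition and higher numbers for weaker inhibition), compound 1 `O=C(CCc1cccc2c1B(O)OC2)Nc1ccc(Cl)cc1` gives 12000 nM and compound 2 `CC(C)(C)OC(=O)NCc1ccc(NC(=O)CCc2cccc3c2B(O)OC3)cc1` gives 2300 nM, the lower of the two numbers so far. Compound 3 `O=C(CCc1cccc2c1B(O)OC2)Nc1ccc([N+](=O)[O-])cc1` differs from compound 2 in one place: nitro in place of ((tert-butoxycarbonyl)amino)methyl on an aromatic carbon. Going by the values given here, the one measured step that bears on this place is a 5.2-fold lower number from compound 1 to compound 2 (0.72 log units; beyond the scatter), where the ((tert-butoxycarbonyl)amino)methyl group replaced chloro. Since that group now leaves again, most of this modest step may reverse, though nitro is not chloro and no nitro value exists for comparison. The expected change is a 3.5-fold higher number from compound 2 to compound 3 (0.54 log units; beyond the scatter), toward a higher number. Compound 3 is estimated at 8000 nM, with an expected range from 2500 nM to 25000 nM.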

Compound 3, half-maximal inhibitory concentration: > 100000 nM
Compound 3 ended at the assay's limit; the forecaster's own chance of this, stated with the estimate: 5%; middle value at least 12-fold (1.09 log units) away from the limit.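

Compound 3 gives no number here, only a limit of the assay: the limit of > 100000 nM in this assay, at which 1 of the 3 values shown sits.

Nitro brings an at least 43-fold higher number from compound 2 to compound 3 (1.63 log units; beyond the scatter) and an at least 8.3-fold higher number from compound 1 to compound 3 (0.92 log units; beyond the scatter) and so sits on the weak side of both chloro and ((tert-butoxycarbonyl)amino)methyl. This place on the aromatic ring can therefore shift activity much further than the earlier modest step suggested, and in the direction of weaker inhibition as well.

The compounds shown leave open whether a free aminomethyl group or a carboxylic acid here would give a lower number than compound 2. Nothing measured here explains the result for nitro.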